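A pyrrole in place of the hydroxyphenyl

This account rests on a few compounds, and the source may have more. Where it says the series, first, only, none or still open, it means among the compounds named here.

Compound 1 `CC1=CC[C@H](C(C)(C)NC(=S)N/N=C/c2ccccc2O)CC1` gives 12100 nM in a functional assay on 786-0 cells (Homo sapiens) for inhibition, read by sulforhodamine B assay, with a stated time of 48 h (a higher number here means a weaker inhibitor of growth, a lower number a stronger inhibitor of growth), the lowest of the two numbers in hand, while compound 2 `COc1cc(/C=N/NC(=S)NC(C)(C)[C@H]2CC=C(C)CC2)ccc1O` gives 35400 nM in this assay. Compound 3 `CC1=CC[C@H](C(C)(C)NC(=S)N/N=C/c2ccccc2[N+](=O)[O-])CC1` reaches only the limit of > 100000 nM in this assay. Replacing hydroxy with nitro on an aromatic carbon therefore gives an at least 8.2-fold higher number from compound 1 to compound 3 (0.91 log units; beyond the scatter), a step that ends at the limit of > 100000 nM in this assay, at which 1 of the 3 values shown sits. Compound 4 `CC1=CC[C@H](C(C)(C)NC(=S)N/N=C/c2ccc[nH]2)CC1` carries 1H-pyrrol-2-yl in place of 2-hydroxyphenyl on a carbon with a double bond to nitrogen, so the hydroxy group is lost here as well. Going by the values given here, only that single measured step bears on the change, and it points toward a higher number. Compound 4 is accordingly expected to be a weaker inhibitor, estimated at 32000 nM (range 10000 nM to 100000 nM). The expected step of a 2.6-fold higher number from compound 1 to compound 4 (0.42 log units; beyond the scatter) is judged likely to exceed the scatter.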

Compound 4, concentration for total growth inhibition: > 100000 nM
Compound 4: only a limit was reported; the forecaster's own chance of this, stated with the estimate: 25%; middle value at least 3.1-fold (0.49 log units) from the limit.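

In this assay compound 4 gives > 100000 nM, which is a limit and not a number. Until now only the nitro-for-hydroxy exchange on the aromatic ring had been seen, whereas here the whole 2-hydroxyphenyl gives way to 1H-pyrrol-2-yl, with an at least 8.2-fold higher number from compound 1 to compound 4 (0.91 log units; beyond the scatter). So a nitro group is not needed for this outcome, and two different changes at this place end at the same ceiling: the limit of > 100000 nM in this assay, at which 2 of the 4 values shown sit.

Compound 3 and compound 4 cannot be ordered, since both rest on that limit. From the compounds shown here alone, whether an amine or a carboxylic acid in place of the hydroxy would keep the growth inhibition stays open.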